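A few compounds are considered here, and "the series" means these few. Any claim that something is new, unique, unknown or untested is made for them only; others in the source may bear on it.

Of the compounds shown here, three built on one shared core have been tested in a functional assay on the whole organism for inhibition, with Rattus norvegicus as the target, at a dose of 1 mg/kg by the oral route; a lower number here means a weaker effect, a higher number a stronger effect of the compound at the dose given. Compound 1 `CC(C)c1ccnc(C(=O)Nc2nn[nH]n2)c1` gives 36%, and compound 3 `Cc1ccc(C)c(C(=O)Nc2nn[nH]n2)n1` gives 37% in this assay. Compound 2 `O=C(Nc1nn[nH]n1)c1cc(Br)ccn1` gives 9% in this assay, the lowest of the three numbers; compound 1 lies nearest to it and compound 3 furthest, and both gaps are beyond the usual scatter. Among the measured compounds only one pair differs in a single place, and that step is a number 27 percentage points lower from compound 1 to compound 2 (beyond the scatter).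

Compound 4 `O=C(Nc1nn[nH]n1)c1cc(Cl)ccn1` has not yet been measured. It differs from compound 2 in one place: chloro in place of bromo on an aromatic carbon. Among the compounds with values here, the one measured step, from compound 1 to compound 2, replaces isopropyl with bromo, so it does not show what exchanging one halogen for another does at this place, and no measured pair compares chloro with bromo. The expectation therefore rests only on the size of the change, one heavy atom leaving and one entering at the same place, with the rest of compound 2 kept. On that basis the step from compound 2 to compound 4 is expected to be a number 2 percentage points higher from compound 2 to compound 4 (within the scatter), within the scatter. Compound 4 is accordingly estimated at 11% in this assay, with a range from 0% to 26%.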

Compound 4, a percentage reported as inhibition, in the whole organism at one dose (the size of the read-out at that dose, not a potency): 38%
Compound 4: the middle estimate sits 27 percentage points below what was measured; the measured number lies above the stated range.
By their numbers in this assay, from the lowest: compound 2; then compounds 1, 3 and 4 (each within the scatter of the next).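

At the place opposite the ring nitrogen, exchanging one halogen for another proves to be no small change in this assay: the swap of bromo for chloro gives a number 29 percentage points higher from compound 2 to compound 4 (beyond the scatter) even though a single heavy atom leaves and a single heavy atom enters. Chloro and isopropyl cannot be told apart at this place, with a number 2 percentage points higher from compound 1 to compound 4 (within the scatter) as the step between them, so the low reading of compound 2 goes with bromo specifically and cannot be assigned to halogens as a class. Nothing available here accounts for the gap between bromo and chloro.

The compounds shown leave open how fluoro or iodo would read at this place, and so whether the halogens follow any order at all or bromo is a lone exception, and how a methoxy or an amine would compare with chloro and isopropyl. On these data alone, since the read-out comes from a single dose in the whole organism, it also remains open whether the gap between compound 2 and compound 4 would hold at other doses.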